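This account rests on a few compounds, and the source may have more. Where it says the series, first, only, none or still open, it means among the compounds named here.

Measured so far in a functional assay on the whole organism (Tail, strain ICR) with Mus musculus as the target, in the tail flick test, with a stated time of 90 min, at a dose of 25 umol/kg by the oral route; on this read-out lower numbers stand for a weaker effect and higher numbers for a stronger effect at the one dose given:
- compound 1 `N=C(N)NCCC[C@H](NC(=O)CN(c1ncnc2c1ncn2C1CCCCO1)C1CC1)C(=O)OCc1ccccc1`: 61.6%
- compound 2 `NC(=O)CC[C@H](NC(=O)CN(c1nc(Cl)nc2[nH]cnc12)C1CC1)C(=O)O`: 41.1%
- compound 3 `O=C(OCc1ccccc1)[C@@H]1CCCN1C(=O)CN(c1ncnc2c1ncn2C1CCCCO1)C1CC1`: 23.3%

Compound 1 stands highest of the three numbers. Its nearest neighbour on this read-out is compound 2, which lies beyond the scatter below it; compound 3 lies further below, also beyond the scatter. No two of the measured compounds differ in only one place, so no single step between them can be isolated; the three numbers show only that, among these analogues, the one bearing the benzyl ester together with the open chain ending in the guanidine-type group gives the largest effect.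

The unmeasured compound 4 `C[C@@H](O)[C@H](NC(=O)CN(c1ncnc2c1ncn2C1CCCCO1)C1CC1)C(=O)OCc1ccccc1` keeps the shared core of compound 1 and its benzyl ester and changes only the side chain: a group of 3 heavy atoms (2 carbon, 1 oxygen; no ring) in place of a group of 7 heavy atoms (4 carbon, 3 nitrogen; no ring), on a saturated chain carbon bound to an amide-type nitrogen and a carbonyl carbon.

Among the measured compounds shown here, with no measured step of this kind available, the expectation rests on the spread of the three numbers. A reduction beyond the scatter is expected, since all departures from compound 1 seen so far lower the read-out, though none of them repeats this particular exchange. For compound 4 the estimated step is a number 21.6 percentage points lower from compound 1 to compound 4 (beyond the scatter). Compound 4 is thus expected to give 40%, within the range 22% to 58%.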

Compound 4, a percentage reported as activity, at one dose (the size of the read-out at that dose, not a potency): 23.4%
The estimate for compound 4 lay 16.6 percentage points above the measured number, and the stated range covers the measured number.
By their numbers in this assay, from the lowest: compounds 3 and 4 (each within the scatter of the next); then compound 2; then compound 1.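

With the shared core and the benzyl ester held fixed, placing 1-hydroxyethyl instead of the group of 7 heavy atoms (4 carbon, 3 nitrogen; no ring), on the saturated chain carbon bound to an amide-type nitrogen and a carbonyl carbon, gives a number 38.2 percentage points lower from compound 1 to compound 4 (beyond the scatter) in this assay. Among the compounds shown here, this is the first single-place comparison, and it shows that the read-out at this dose is sensitive to the group at this position, which the earlier compounds, each differing in more than one place, could not show. No measurement available here accounts for the size of this step.

The exchange alters chain length, heteroatom content and hydrogen-bond donor count together, so the compounds shown do not separate the contribution of the chain from that of the guanidine-type group at its end. Open questions are how an aminobutyl chain or a plain butyl chain would read at this position on the same core and benzyl ester, and whether either would stay near the value of compound 1 or that of compound 4.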